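The source may report more compounds than this note shows. Statements on the series, on what has been measured and on what is new or still open speak of the compounds shown alone.

Working notes on the series, read in a functional assay on K562 cells (Homo sapiens) for inhibition, read by trypan blue exclusion, with a stated time of 72 h; a lower number here means a stronger inhibitor, a higher number a weaker inhibitor. Compound 1 (`Cn1c(=O)c(S(=O)(=O)c2ccc(C(=O)O)cc2)cc2cnc(Nc3ccc4[nH]ccc4c3)nc21`) gives 5000 nM. Compound 2 (`COc1ccc(Nc2ncc3cc(S(=O)(=O)c4ccc(Cl)cc4)c(=O)n(C)c3n2)cc1`) gives 15000 nM. Compound 3 (`Cn1c(=O)c(S(=O)(=O)c2ccc(F)cc2F)cc2cnc(Nc3ccc4c(c3)CC(=O)N4)nc21`) gives 15000 nM, level with compound 2 and at the high end of the three numbers, while compound 1 stands lower, a gap beyond the scatter.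

Compound 4 (`Cn1c(=O)c(S(=O)(=O)c2ccc(F)cc2F)cc2cnc(Nc3ccc4c(c3)C(=O)C(=O)N4)nc21`) is the next entry, and its structural change from compound 3 is a group of 11 heavy atoms (8 carbon, 1 nitrogen, 2 oxygen; one five-membered non-aromatic ring with 1 hetero atom, one six-membered aromatic ring of carbon only) in place of a group of 10 heavy atoms (8 carbon, 1 nitrogen, 1 oxygen; one five-membered non-aromatic ring with 1 hetero atom, one six-membered aromatic ring of carbon only), on a nitrogen on an aromatic ring. For the measured compounds named here, no measured pair differs in one place, so nothing here sizes this change directly. Going by the values given here, the only guide in this assay is the narrow spread of the three measured compounds, with compound 3 at 15000 nM and compound 1 at 5000 nM. No step beyond the scatter is expected, in either direction. The estimated step of a 1.3-fold lower number from compound 3 to compound 4 (0.10 log units; within the scatter) is small and within the scatter. For compound 4 the expected value is 12000 nM, with an estimated range from 4000 nM to 30000 nM.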

Compound 4, half-maximal inhibitory concentration: 30000 nM
For compound 4 the middle estimate is 2.5-fold (0.40 log units) below the measured one; measured number inside the range.
By their numbers in this assay, from the lowest: compound 1; then compounds 2, 3 and 4 (each within the scatter of the next).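

In this assay, the series now has its first readable step, a 2.0-fold higher number from compound 3 to compound 4 (0.30 log units; within the scatter), for a change made on a nitrogen on an aromatic ring. At this place, the group of 11 heavy atoms, with 2 double bonds outside aromatic rings and 2 hydrogen-bond acceptors, leaves compound 4 within the scatter of compound 3, whose group of 10 heavy atoms has 1 of each; the hydrogen-bond donor count and the ring types are the same in both groups. No measurement offered here accounts for this step.

Open, as far as these compounds go, is how a group at this place carrying an amine or a morpholine would read. Also open, from the compounds shown here alone, is whether the same change would give a step of similar size on other members.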